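Trifluoromethyl on the ester analogue of the tricyclic acid series

The source may report more compounds than this note shows. Statements on the series, on what has been measured and on what is new or still open speak of the compounds shown alone.

Measured so far:
compound 1, `O=C(O)c1ccc2ccc(C(=O)c3ccccc3)c-2cc1`, 32.9%
compound 2, `O=C(O)c1ccc2ccc(C(=O)c3ccc(C(F)(F)F)cc3)c-2cc1`, 1%
compound 3, `COC(=O)Cc1ccc2ccc(C(=O)c3ccccc3)c-2cc1`, -4.3%

In an assay on cells for displacement of a labelled ligand from Orexin receptor type 2 (Homo sapiens), read by scintillation counting, with stated times of 10 min and 90 min, tested at 10 uM (a higher number here means more inhibition at the concentration tested (going by the name of the read-out), a lower number less inhibition), compound 1 gives 32.9%. Compound 2 differs from compound 1 by trifluoromethyl in place of hydrogen on an aromatic carbon, and this change gives a number 31.9 percentage points lower from compound 1 to compound 2 (beyond the scatter). Compound 3 differs from compound 1 by (methoxycarbonyl)methyl in place of carboxy on an aromatic carbon, and this change gives a number 37.2 percentage points lower from compound 1 to compound 3 (beyond the scatter). Compound 3 and compound 2 lie within the scatter of each other, so no order between them is claimed; both stand well under compound 1.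

Compound 4, `COC(=O)Cc1ccc2ccc(C(=O)c3ccc(C(F)(F)F)cc3)c-2cc1`, has not yet been measured in this assay. It differs from compound 3 by trifluoromethyl in place of hydrogen on an aromatic carbon, which is the same change as that from compound 1 to compound 2; the place description is identical in both cases, and the change occurs twice among the compounds shown. How the two cores differ is given by (methoxycarbonyl)methyl in place of carboxy on an aromatic carbon.

The earlier step, a number 31.9 percentage points lower from compound 1 to compound 2 (beyond the scatter), was large, but it started from compound 1, which gives 32.9%. Compound 3 already gives -4.3%, close to the lower end of what this read-out reports, so little room for a further fall remains. The step expected on this basis is a number 4.3 percentage points higher from compound 3 to compound 4 (within the scatter), much smaller than the earlier one and within the scatter. Compound 4 is therefore expected to give about 0% in this assay, estimated between -15% and 12%.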

Compound 4, a percentage reported as inhibition, at one concentration (the size of the read-out at that concentration, not a potency): 1%
Beside the measured number, compound 4's estimate is 1 percentage points below it; measured number inside the range.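

In this assay, trifluoromethyl in place of hydrogen on an aromatic carbon gives a number 5.3 percentage points higher from compound 3 to compound 4 (within the scatter), and this does not repeat the earlier step on the core of compound 1: the same change on two cores in this assay, a number 31.9 percentage points lower (beyond the scatter) from compound 1 to compound 2 and a number 5.3 percentage points higher (within the scatter) from compound 3 to compound 4, 37.2 percentage points apart, beyond the scatter of two such steps

Read across the other edge of the same four compounds, (methoxycarbonyl)methyl in place of carboxy gives no change at the digits printed from compound 2 to compound 4 (within the scatter), and this too does not repeat its earlier step: the same change on two cores in this assay, a number 37.2 percentage points lower (beyond the scatter) from compound 1 to compound 3 and no change at the digits printed (within the scatter) from compound 2 to compound 4, 37.2 percentage points apart, beyond the scatter of two such steps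

So neither change can be carried from one core to the other in this series as a fixed step, although this rests on a single set of four compounds read at one concentration, which gives no potencies and does not show what lies behind the difference or how either change would behave on a further core.

Still open, on these data alone, is whether a carboxylic acid on the same one-carbon chain, in place of the methyl ester, would stay near compound 1 or fall away, which would separate the part played by the ester from that of the longer chain. Also open, as far as these compounds go, is whether a chlorine or a methoxy group in place of trifluoromethyl would produce the same fall on the core of compound 1.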